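The source may report more compounds than this note shows. Statements on the series, on what has been measured and on what is new or still open speak of the compounds shown alone.

Working notes on the series. Compound 1 `COc1cc2ncnc(Nc3ccc(F)c(Cl)c3)c2cc1OCCCCC(=O)Nc1ccc(S(N)(=O)=O)cc1` gives 35600 nM in a functional assay on NCI-H1975 cells (Homo sapiens) for antiproliferative activity, read by MTT assay, with a stated time of 72 h (on this read-out lower numbers stand for stronger inhibition and higher numbers for weaker inhibition), the highest number of the three measured compounds. Compound 2 `COc1cc2ncnc(Nc3ccc(Cl)c(C(F)(F)F)c3)c2cc1OCCCCC(=O)Nc1ccc(S(N)(=O)=O)cc1` gives 3220 nM and compound 3 `COc1cc2ncnc(Nc3cccc(Br)c3)c2cc1OCCCCC(=O)Nc1ccc(S(N)(=O)=O)cc1` gives 11400 nM. The shared core and the chain to the sulfonamide are kept throughout; only the aryl group on the amine nitrogen varies. Between the measured compounds, an 11-fold lower number from compound 1 to compound 2 (1.04 log units; beyond the scatter), a 3.1-fold lower number from compound 1 to compound 3 (0.49 log units; beyond the scatter), and a 3.5-fold higher number from compound 2 to compound 3 (0.55 log units; beyond the scatter).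

Compound 4 `COc1cc2ncnc(Nc3cccc(Cl)c3)c2cc1OCCCCC(=O)Nc1ccc(S(N)(=O)=O)cc1` is not yet measured in this assay. Relative to compound 1 the change is hydrogen in place of fluoro on an aromatic carbon. Among the measured compounds shown here, no measured step removes a fluoro alone. The closest comparison is compound 3, because a 3.1-fold lower number from compound 1 to compound 3 (0.49 log units; beyond the scatter) shows a modest gain on going from 3-chloro-4-fluorophenyl to the single-halogen 3-bromophenyl, and 3-chlorophenyl is the chloro counterpart of that group. A step of similar size, downward, is therefore expected, but a value within the scatter of compound 1 cannot be excluded. Compound 4 is estimated at 13000 nM, with a range of 5000 nM to 32000 nM. This corresponds to an expected step of a 2.7-fold lower number from compound 1 to compound 4 (0.44 log units; beyond the scatter).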

Compound 4, half-maximal inhibitory concentration: 33200 nM
For compound 4 the middle estimate is 2.6-fold (0.41 log units) below the measured one; the whole stated range lies below it.
By their numbers in this assay, from the lowest: compound 2; then compound 3; then compounds 4 and 1 (each within the scatter of the next).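

In this assay, hydrogen in place of fluoro on this aromatic carbon leaves the number unchanged within the scatter, with a 1.1-fold lower number from compound 1 to compound 4 (0.03 log units; within the scatter), so removing the fluoro alone does not reproduce the gain seen with the 3-bromophenyl group. The single-halogen pair now separates instead, with a 2.9-fold higher number from compound 3 to compound 4 (0.46 log units; beyond the scatter) for chloro in place of bromo, while 3-chlorophenyl remains well apart from 4-chloro-3-(trifluoromethyl)phenyl, with a 10-fold higher number from compound 2 to compound 4 (1.01 log units; beyond the scatter). No available evidence gives a reason for any of these steps.

The compounds shown leave open whether a methyl, a methoxy or a nitrile on this aromatic carbon would read differently from hydrogen and fluoro. They also leave open whether fluoro and hydrogen would still read alike with a bromo or a trifluoromethyl group in place of the chloro.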